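This account rests on a few compounds, and the source may have more. Where it says the series, first, only, none or still open, it means among the compounds named here.

Of the compounds shown here, three built on one shared core have been tested in a functional assay on MCF7 cells (Homo sapiens) for inhibition, read by MTT assay, with a stated time of 72 h; a higher number here means a weaker inhibitor, a lower number a stronger inhibitor. Compound 1 `O=C1Nc2ccc(Br)cc2/C1=N/NC(=S)N1CCN(c2ccccc2)CC1` gives 20500 nM. Compound 2 `O=C1Nc2ccc(Cl)cc2/C1=N/NC(=S)N1CCN(c2ccccc2)CC1` gives in this assay 10400 nM. The only difference between these two is chloro in place of bromo on an aromatic carbon, and that change produced a 2.0-fold lower number from compound 1 to compound 2 (0.29 log units; within the scatter). Compound 3 `O=C1Nc2cccc(Br)c2/C1=N/NC(=S)N1CCN(c2ccccc2)CC1` is built from the same atoms as compound 1, joined differently; how the two cores differ is not broken down here. In this assay compound 3 gives 40700 nM, a number that lies within the scatter of the value of compound 1 but beyond the scatter relative to the value of compound 2.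

Compound 4 `O=C1Nc2cccc(Cl)c2/C1=N/NC(=S)N1CCN(c2ccccc2)CC1` has not yet been measured. It differs from compound 3 by chloro in place of bromo on an aromatic carbon. Among the compounds with values here, this is the same kind of change as the one between compound 1 and compound 2, although the place is not the same: in the earlier pair the carbon is meta to a fused ring and para to a fused ring, whereas here it is ortho to a fused ring and meta to a fused ring. The change has occurred only once among the measured compounds, so the expectation rests on a single observation.

Within the data shown here, compound 4 is expected to show a 1.9-fold lower number from compound 3 to compound 4 (0.27 log units; within the scatter), because the one measured instance of this kind of change gave a 2.0-fold lower number from compound 1 to compound 2 (0.29 log units; within the scatter). For compound 4 the estimate is 22000 nM, with a likely range from 10000 nM to 50000 nM.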

Compound 4, half-maximal inhibitory concentration: 52100 nM
Estimate against measurement, compound 4: 2.4-fold (0.37 log units) below, and the stated range ends below it.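

In this assay, putting chloro in place of bromo on the aromatic carbon ortho to a fused ring and meta to a fused ring gives a 1.3-fold higher number from compound 3 to compound 4 (0.11 log units; within the scatter), so this step on its own cannot be told apart from repeat measurement. Set beside the earlier pair, the step points the other way in its printed direction, yet the two steps cannot be separated from each other: the same change on two cores in this assay, a 2.0-fold lower number (0.29 log units; within the scatter) from compound 1 to compound 2 and a 1.3-fold higher number (0.11 log units; within the scatter) from compound 3 to compound 4, 2.5-fold (0.40 log units) apart, within the scatter of two such steps. Within the data shown here, this shows that, across these two pairs, the exchange of bromo for chloro has no effect in this assay that stands clear of the scatter on either core, and that the two cores give no measurable sign of treating it differently, but it does not show that the change carries over reliably, nor that it truly depends on the core, since each core supplies only one small step.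

The compounds shown carry only bromo or chloro on the aromatic ring, so it stays open whether fluoro, methoxy, nitro or a plain hydrogen at either place would give a step beyond the scatter. Going by these compounds, it also stays open whether an amine or a carboxylic acid on the phenyl group would move the number more than either halogen exchange does.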